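Cytotoxicity notes: aryl swap on the shared core

The source may report more compounds than this note shows. Statements on the series, on what has been measured and on what is new or still open speak of the compounds shown alone.

The series shares the core seen in compound 1 `COc1ccc([C@@H]2CC(=O)C[C@H](c3ccco3)C23C(=O)OC(C)(C)OC3=O)cc1` and compound 2 `CC1(C)OC(=O)C2(C(=O)O1)[C@@H](c1ccco1)CC(=O)C[C@H]2c1ccc(F)cc1`, which differ by fluoro in place of methoxy on an aromatic carbon. In an ADME assay on MT2 cells (Homo sapiens) for cytotoxicity (a higher number here means that more compound is tolerated, a lower number that less compound is tolerated), compound 1 gives > 111000 nM, a limit of the assay and not a number. In this assay compound 2 likewise gives > 111000 nM, again a limit. The step that the two limits leave unreadable from compound 1 to compound 2 is therefore of unreadable size; both values sit at the limit of > 111000 nM in this assay, at which 2 of the 2 values shown sit.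

Compound 3 `COc1ccc([C@@H]2CC(=O)C[C@H](c3ccco3)C23C(=O)OC(C)(C)OC3=O)cc1OC` is the next member of the series: 3,4-dimethoxyphenyl in place of 4-fluorophenyl on a saturated ring carbon. Among the compounds with values here, only one measured step exists, from compound 1 to compound 2, and its size is unreadable, so no measured step gives a size for the present change. Both measured compounds rest at the limit, and compound 3 is expected to do the same, so the expected step that the limit leaves unreadable from compound 2 to compound 3 is none beyond the scatter. For compound 3 the estimate in this assay is 150000 nM, within 70000 nM to 400000 nM, with a high chance that only a limit is reported again.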

Compound 3, half-maximal cytotoxic concentration: > 111000 nM
Compound 3: a limit, no number; the forecaster's own chance of this, stated with the estimate: 80%; the middle value does not contradict the limit.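

In this assay compound 3 gives > 111000 nM, again a limit and not a number. Within the data shown here, no step among compound 1, compound 2 and compound 3 can be read, as all three rest at the same limit: the limit of > 111000 nM in this assay, at which 3 of the 3 values shown sit. The compounds shown leave open whether these aryl groups on the shared core differ at all in this assay, as none gives a number.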